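Hydroxamic Acids with Aryl Side Chains Against Colon Cells

This account rests on a few compounds, and the source may have more. Where it says the series, first, only, none or still open, it means among the compounds named here.

Three hydroxamic acids have been measured in a functional assay on HCT-15 cells (Homo sapiens) for inhibition, read by sulforhodamine B assay; on this read-out higher numbers stand for weaker inhibition of growth and lower numbers for stronger inhibition of growth. Compound 1 `O=C(CCC1=CCN(CCCc2ccc(Cl)cc2)C1=O)NO` gives 5100 nM in this assay. Compound 2 `CC(C)(C)c1ccc(CCCN2CC=C(CCC(=O)NO)C2=O)cc1` carries a tert-butyl in place of chloro on an aromatic carbon, and in this assay compound 2 gives 5100 nM. The step in this assay is no change at the digits printed from compound 1 to compound 2 (within the scatter); the change behind it is tert-butyl in place of chloro on an aromatic carbon. Compound 3 `O=C(CCC1=CCN(Cc2ccc(Cl)cc2)C1=O)NO` gives 4720 nM in this assay. The difference between the core of compound 1 and the core of compound 3 is not broken down here; the two values show nothing that lies beyond the usual scatter.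

Compound 4 `CC(C)(C)c1ccc(CN2CC=C(CCC(=O)NO)C2=O)cc1` has not yet been measured in this assay. Within the data shown here, it stands to compound 3 as compound 2 stands to compound 1: the change is tert-butyl in place of chloro on an aromatic carbon, and it is the same change as the one from compound 1 to compound 2, since the two places match word for word. Because the step of no change at the digits printed from compound 1 to compound 2 (within the scatter) stayed within the scatter, the step from compound 3 to compound 4 is expected to be small as well, a 1.0-fold higher number from compound 3 to compound 4 (0.01 log units; within the scatter). In this assay, among the measured compounds shown here, compound 4 is therefore estimated to give 4800 nM, with a range from 2400 nM to 9600 nM, a guess that rests on the single measured instance of this change.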

Compound 4, concentration for 50% growth inhibition: 570 nM
Beside the measured number, compound 4's estimate is 8.4-fold (0.93 log units) above it; the whole stated range lies above it.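

On the core of compound 3, tert-butyl in place of chloro on the aromatic carbon gives an 8.3-fold lower number from compound 3 to compound 4 (0.92 log units; beyond the scatter) in this assay, whereas the same change left the earlier pair unchanged at the digits printed. The two steps therefore cannot be treated as one transferable increment, and the flat result on the core of compound 1 did not predict the result on the core of compound 3: the same change on two cores in this assay, no change at the digits printed (within the scatter) from compound 1 to compound 2 and an 8.3-fold lower number (0.92 log units; beyond the scatter) from compound 3 to compound 4, 8.3-fold (0.92 log units) apart, beyond the scatter of two such steps. This shows that, in these two matched pairs, the size of the step differs with the core, but it does not show which feature of the cores accounts for the difference, and two pairs establish no rule for any further core in the series.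

The compounds shown leave open whether the gain seen with tert-butyl on the core of compound 3 would also appear with another group at that aromatic carbon, such as trifluoromethyl, methoxy or an amine. They also leave open how the same exchange of chloro for tert-butyl would behave on a core with a side chain of another length, or with a carboxylic acid in place of the hydroxamic acid.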